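The source may hold more compounds than are shown below. What is called first, only, known or untested is meant among the compounds shown, and "the series" means these compounds.

Of the compounds shown here, three have been measured in a physicochemical assay for lipophilicity; on this read-out lower numbers stand for lower lipophilicity and higher numbers for higher lipophilicity. Compound 1 `C/C(=C\C(=O)O)C(=O)c1ccc(C)cc1` gives 2.94, and compound 2 `C/C(=C/C(=O)O)C(=O)c1ccccc1` gives 1.69. Compound 3 `CCCCC(=O)/C(C)=C(/C)C(=O)O` gives 0.9, the lowest of the three numbers, with compound 2 nearest and compound 1 furthest, both beyond the scatter above it. Compound 4 `CCCCCCCC(=O)/C(C)=C(/C)C(=O)O` has not yet been measured in this assay. It differs from compound 3 in one place: propyl in place of hydrogen on a saturated chain carbon, four bonds along the chain from a carbonyl carbon. Going by the values given here, no step between two measured compounds bears on this change, so the expectation rests on the change alone. The step from compound 3 to compound 4 is expected to be a number 1.50 log units higher from compound 3 to compound 4 (beyond the scatter), upward and beyond the scatter. Compound 4 is therefore estimated at 2.4, in the range from 1.9 to 2.9.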

Compound 4, partition coefficient: 2.4
Beside the measured number, compound 4's estimate shows no gap at the digits printed; low and high end bracket the measured number.
By their numbers in this assay, from the lowest: compound 3; then compound 2; then compound 4; then compound 1.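

In this assay the chain position four bonds along from a carbonyl carbon responds strongly to propyl in place of hydrogen, with a large upward step (a number 1.50 log units higher from compound 3 to compound 4 (beyond the scatter)). Going by these compounds alone, this is the first step between measured compounds that differ in one place, so it gives the study its first reading of a single change. Nothing measured here accounts for the size of this step. The compounds shown leave open how an ethyl, a longer chain, or a hydroxyl or an amine at this place would read out.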